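This account rests on a few compounds, and the source may have more. Where it says the series, first, only, none or still open, it means among the compounds named here.

Measured so far in an ADME assay on HEp-2 cells (Homo sapiens) for cytotoxicity; on this read-out lower numbers stand for higher toxicity in this test and higher numbers for lower toxicity in this test:
- Compound 1 `CCc1ccccc1NC(=O)[C@@H]1CCCN1S(=O)(=O)c1cccc2cccnc12`: > 50000 nM (a limit of the assay)
- Compound 2 `Cc1ccc(Cl)cc1NC(=O)[C@@H]1CCCN1S(=O)(=O)c1cccc2cccnc12`: 10000 nM

Among the compounds with values here, compound 2, at 10000 nM, holds the only actual number so far. Compound 3 `COc1ccc(C)cc1NC(=O)[C@@H]1CCCN1S(=O)(=O)c1cccc2cccnc12` carries 2-methoxy-5-methylphenyl in place of 5-chloro-2-methylphenyl on an amide-type nitrogen. One measured step changes the group at that place, an at least 5.0-fold lower number from compound 1 to compound 2 (0.69 log units; beyond the scatter), and it lies beyond the scatter. On that single step, a modest move to a higher number in this assay is expected, meaning lower toxicity in this test. The expected step is a 2.5-fold higher number from compound 2 to compound 3 (0.40 log units; beyond the scatter). Compound 3 is estimated at 25000 nM, within an expected range of 9000 nM to 50000 nM.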

Compound 3, half-maximal cytotoxic concentration: > 50000 nM
Compound 3 gave a limit, no number; the forecaster's own chance of this, stated with the estimate: 35%; middle value at least 2.0-fold (0.30 log units) from the limit.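

In this assay, putting 2-methoxy-5-methylphenyl in place of 5-chloro-2-methylphenyl on the amide-type nitrogen gives an at least 5.0-fold higher number from compound 2 to compound 3 (0.69 log units; beyond the scatter), so a second group at this place, after 2-ethylphenyl, reads higher than 5-chloro-2-methylphenyl. Compound 3 gives > 50000 nM, which is a limit of the assay. The step between compound 1 and compound 3 cannot be read, and the set largely rests at that limit: the limit of > 50000 nM in this assay, at which 2 of the 3 values shown sit.

From the compounds shown here alone, how far compound 1 and compound 3 truly lie from compound 2 stays open. So does the reading for a phenyl group bearing an amine or a carboxylic acid at this place.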